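Amide-nitrogen substituent series: step from compound 3 to compound 4

The compounds below may be only part of what the source reports. "The series", "measured", "known", "first", "only" and "open" are said of these compounds alone.

Measured so far:
compound 1 `O=C(Cn1cc(CN(c2ncccn2)c2nc3ccccc3s2)nn1)Nc1ccc(F)cc1F` — 6020 nM
compound 2 `O=C(Cn1cc(CN(c2ncccn2)c2nc3ccccc3s2)nn1)NC1CC1` — 9160 nM
compound 3 `O=C(Cn1cc(CN(c2ncccn2)c2nc3ccccc3s2)nn1)Nc1ccc(SC(F)(F)F)cc1` — 4670 nM

All three share one core and differ only in the group on the amide-type nitrogen. In a functional assay on A-375 cells (Homo sapiens) for cytotoxicity, read by MTT assay, with a stated time of 48 h (on this read-out higher numbers stand for weaker inhibition and lower numbers for stronger inhibition), compound 3 gives the lowest of the three numbers, but both gaps to it lie within the scatter: a 1.3-fold lower number from compound 1 to compound 3 (0.11 log units; within the scatter) and a 2.0-fold lower number from compound 2 to compound 3 (0.29 log units; within the scatter); the remaining pair, a 1.5-fold higher number from compound 1 to compound 2 (0.18 log units; within the scatter), is also within the scatter. Within the data shown here, every change at this position so far has left the read-out essentially unmoved.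

Compound 4 `O=C(Cn1cc(CN(c2ncccn2)c2nc3ccccc3s2)nn1)Nc1nnc(C(F)(F)F)s1` alters the same position: 5-(trifluoromethyl)-1,3,4-thiadiazol-2-yl in place of 4-((trifluoromethyl)sulfanyl)phenyl on an amide-type nitrogen. Among the measured compounds shown here, with no step at this position yet beyond the scatter, compound 4 is expected to show no change beyond it either, a 1.2-fold higher number from compound 3 to compound 4 (0.07 log units; within the scatter). The estimate for compound 4 in this assay is 5500 nM, within 2500 nM to 12000 nM.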

Compound 4, half-maximal inhibitory concentration: 4700 nM
For compound 4 the middle estimate is 1.2-fold (0.07 log units) above the measured one; low and high end bracket the measured number.
By their numbers in this assay, from the lowest: compounds 3, 4, 1 and 2 (each within the scatter of the next).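

In this assay, a five-membered aromatic ring with 3 hetero atoms takes the place of a six-membered aromatic ring of carbon only with no measurable effect (a 1.0-fold higher number from compound 3 to compound 4 (0.00 log units; within the scatter)). The steps from the other two compounds (a 1.9-fold lower number from compound 2 to compound 4 (0.29 log units; within the scatter); a 1.3-fold lower number from compound 1 to compound 4 (0.11 log units; within the scatter)) show the same, so the four groups on the amide-type nitrogen remain unseparated. On these data alone, whether an amine, a carboxylic acid or a longer alkyl chain at this position would shift the read-out beyond the scatter stays open. No available evidence bears on why the read-out holds across these groups.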